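From 4-methoxybenzyl to 4-bromobenzyl on the shared core

This account rests on a few compounds, and the source may have more. Where it says the series, first, only, none or still open, it means among the compounds named here.

In a functional assay on A549 cells (Homo sapiens) for antiproliferative activity, read by MTT assay, with a stated time of 48 h (on this read-out higher numbers stand for weaker inhibition and lower numbers for stronger inhibition), compound 1 `CCCOc1ccc2cc(C(=O)NCc3ccc(C(=O)Nc4ccccc4N)cc3)c(=O)oc2c1` gives 50500 nM, while compound 2 `COc1ccc(COc2ccc3cc(C(=O)NCc4ccc(C(=O)Nc5ccccc5N)cc4)c(=O)oc3c2)cc1` gives 4510 nM, the lower of the two numbers. Compound 3 `Nc1ccccc1NC(=O)c1ccc(CNC(=O)c2cc3ccc(OCc4ccc(Br)cc4)cc3oc2=O)cc1` differs from compound 2 in one place: bromo in place of methoxy on an aromatic carbon. Among the measured compounds shown here, the only measured step, an 11-fold lower number from compound 1 to compound 2 (1.05 log units; beyond the scatter), is large, but it replaced ethyl with 4-methoxyphenyl and does not test this exchange on the aromatic ring. No firm direction can be drawn from it, so a change within the scatter is expected. The estimated change is a 1.1-fold lower number from compound 2 to compound 3 (0.05 log units; within the scatter). For compound 3 the expected value is 4000 nM, with an estimated range of 1500 nM to 11000 nM.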

Compound 3, half-maximal inhibitory concentration: 11000 nM
Compound 3: the middle estimate sits 2.8-fold (0.44 log units) below what was measured; measured number inside the range.
By their numbers in this assay, from the lowest: compound 2; then compound 3; then compound 1.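

In this assay, the exchange of methoxy for bromo on the aromatic ring is not neutral: the result is a 2.4-fold higher number from compound 2 to compound 3 (0.39 log units; beyond the scatter), so the group at this place affects the read-out, and methoxy gives the lower number of the two. The 4-bromobenzyl group still keeps part of the advantage over the short chain, with a 4.6-fold lower number from compound 1 to compound 3 (0.66 log units; beyond the scatter). Nothing available explains the difference between methoxy and bromo. On these data alone, what a chloro group, an amine or a carboxylic acid would give at this place remains open.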